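The compounds below may be only part of what the source reports. "The series", "measured", "known", "first", "only" and "open" are said of these compounds alone.

Compound 1 `Oc1ccc(-c2cc(-c3ccsc3)cc(-c3ccccc3O)n2)cc1` in a functional assay on HCT-15 cells (Homo sapiens) for cytotoxicity, read by CCK-8 assay; on this read-out lower numbers stand for stronger inhibition and higher numbers for weaker inhibition: > 50000 nM, which is a limit of the assay rather than a number.
Compound 2 `Oc1ccc(-c2cc(-c3ccsc3)cc(-c3cccc(O)c3)n2)cc1` in this assay: 1180 nM.

Compound 2 therefore stands as the only numbered result; the other value shown is a limit (the limit of > 50000 nM in this assay, at which 1 of the 2 values shown sits). Going by the values given here, the one measured step, an at least 42-fold lower number from compound 1 to compound 2 (1.62 log units; beyond the scatter), came with 3-hydroxyphenyl in place of 2-hydroxyphenyl on an aromatic carbon. Compound 3 `Oc1ccc(-c2cc(-c3cccnc3)cc(-c3cccc(O)c3)n2)cc1` differs from compound 2 in a different place: pyridin-3-yl in place of thiophen-3-yl on an aromatic carbon. Among the compounds with values here, no measured step touches the thiophen-3-yl group, so none bears directly on this exchange, and a step within the scatter, in either direction, is expected in this assay. Compound 3 is estimated at 1500 nM, in a range from 500 nM to 5000 nM. That estimate means an expected 1.3-fold higher number from compound 2 to compound 3 (0.10 log units; within the scatter).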

Compound 3, half-maximal inhibitory concentration: > 50000 nM
Compound 3 gave a limit, no number; the forecaster's own chance of this, stated with the estimate: 5%; middle value at least 33-fold (1.52 log units) from the limit.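

In this assay, the position opposite the ring nitrogen proved sensitive to the identity of the aromatic ring: pyridin-3-yl in place of thiophen-3-yl gave an at least 42-fold higher number from compound 2 to compound 3 (1.62 log units; beyond the scatter). From the compounds shown here alone, compound 3 gives > 50000 nM, which is a limit of the assay and not a number, so the full size of this step stays unknown. Compound 2 alone keeps a number: the limit of > 50000 nM in this assay, at which 2 of the 3 values shown sit.

The compounds shown leave open whether a phenyl, furan-3-yl or thiophen-2-yl group at this place would retain a numbered value. They also leave open whether the loss follows from the ring nitrogen or from the change in ring size.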